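A Smaller Halogenated Ring on the Shared Core

A few compounds are considered here, and "the series" means these few. Any claim that something is new, unique, unknown or untested is made for them only; others in the source may bear on it.

Compound 2 `NS(=O)(=O)c1ccc(NC(=S)Nc2ccc3ncnc(Nc4ccc(C(F)(F)F)cc4)c3c2)cc1` carries a sulfonamide-bearing thiourea on a shared core. In a functional assay on A549 cells (Homo sapiens) for antiproliferative activity, read by MTT assay, with a stated time of 72 h (on this read-out lower numbers stand for stronger inhibition and higher numbers for weaker inhibition), compound 2 gives > 40000 nM, which is a limit of the assay rather than a number. Compound 1 `NS(=O)(=O)c1ccc(NC(=S)Nc2ccc3ncnc(Nc4ccc(F)c(Br)c4)c3c2)cc1` gives > 40000 nM in this assay, also a limit. The step that the two limits leave unreadable from compound 1 to compound 2 cannot be read, as the limit of > 40000 nM in this assay, at which 2 of the 2 values shown sit, shows. Compound 3 `NS(=O)(=O)c1ccc(NC(=S)Nc2ccc3ncnc(Nc4cccc(F)c4)c3c2)cc1` differs from compound 2 in one place: 3-fluorophenyl in place of 4-(trifluoromethyl)phenyl on a nitrogen on an aromatic ring. Within the data shown here, no measured step gives a readable size for this change, so no direction beyond the scatter can be expected. Compound 3 is therefore estimated at 30000 nM (range 4000 nM to 80000 nM), a step of an at least 1.3-fold lower number from compound 2 to compound 3 (0.12 log units; that floor lies within the scatter) expected to stay near the limit.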

Compound 3, half-maximal inhibitory concentration: 25900 nM
Beside the measured number, compound 3's estimate is 1.2-fold (0.06 log units) above it, and the stated range covers the measured number.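

With 3-fluorophenyl on the nitrogen, compound 3 gives the first number rather than a limit, so a change at this position can now be partly read. The change gives an at least 1.5-fold lower number from compound 2 to compound 3 (0.18 log units; that floor lies within the scatter) and an at least 1.5-fold lower number from compound 1 to compound 3 (0.18 log units; that floor lies within the scatter) as its two steps. Going by these compounds, each size is only a floor, and the full size of either step stays unknown: the limit of > 40000 nM in this assay, at which 2 of the 3 values shown sit.

The step between compound 1 and compound 2 remains unreadable. Also open, on these data alone, is how the number would move with an amine or a carboxylic acid on the ring attached to this nitrogen.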